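This account rests on a few compounds, and the source may have more. Where it says the series, first, only, none or still open, it means among the compounds named here.

Compound 2 `COc1ccc2c(c1)C[C@H](C(=O)Nc1ccc(-c3cn[nH]c3)cc1O[C@@H]1CCN(C)C1)CO2` is the more potent of the two measured epimers at the chroman stereocentre. In an assay on isolated protein for inhibition of Rho-associated protein kinase 2 (Homo sapiens), read by HTRF, with a stated time of 4 h (on this read-out lower numbers stand for stronger inhibition and higher numbers for weaker inhibition), compound 2 reaches only the limit of the assay, < 1 nM, so its true value is not known. Its epimer compound 1 `COc1ccc2c(c1)C[C@@H](C(=O)Nc1ccc(-c3cn[nH]c3)cc1O[C@@H]1CCN(C)C1)CO2` gives 14 nM in this assay, and the step of an at least 14-fold lower number from compound 1 to compound 2 (1.14 log units; beyond the scatter) shows how much the configuration at that saturated ring carbon matters.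

Compound 3 `COc1ccc2c(c1)C[C@H](C(=O)Nc1ccc(-c3cn[nH]c3)cc1O[C@H]1CCN(C)C1)CO2` keeps the favoured chroman configuration of compound 2 and changes the other centre: the two compounds have the same atoms and bonds and differ only in configuration as drawn: 1 of 2 stereo elements differ; a stereocentre at a saturated ring carbon is drawn R in compound 2 and S in compound 3, at the saturated ring carbon of the aminopyrrolidine ether. Among the compounds with values here, no measured step tests this second stereocentre; the only measured step, from compound 1 to compound 2, concerns the other one, and it was large. Because the value of compound 2 is a limit (the limit of < 1 nM in this assay, at which 1 of the 2 values shown sits), a step in either direction is hard to size. Compound 3 is expected to lose some potency, an at least 4.0-fold higher number from compound 2 to compound 3 (0.60 log units; beyond the scatter), with the estimate for compound 3 in this assay at 4 nM, within 0.6 nM to 30 nM.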

Compound 3, half-maximal inhibitory concentration: < 1 nM
Compound 3: a limit, no number (the forecaster's own chance of this, stated with the estimate: 25%); middle value at least 4.0-fold (0.60 log units) away from the limit.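

In this assay compound 3 gives < 1 nM, which is a limit of the assay and not a number. Compound 2 also stands at that limit, so the step between the two cannot be read, and inverting the saturated ring carbon of the aminopyrrolidine ether, with the other stereocentre held as in compound 2, leaves the compound at the limit rather than producing a readable loss. Inverting both stereocentres gives an at least 14-fold lower number from compound 1 to compound 3 (1.14 log units; beyond the scatter), and this large step can be put down to configuration alone: the fact that compounds 1 and 3 differ only in the configuration as drawn

From the compounds shown here alone, what stays open is whether the ether stereocentre has any effect on the true potency, since any difference between compound 2 and compound 3 lies out of reach of this read-out, and a real one could still be hidden there. Also open, going by these compounds, is how a primary amine, a carboxylic acid or a longer chain in place of the methylpyrrolidine ether would read in this assay, and whether the preference at this stereocentre would then become visible.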